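Replacing the Aromatic Group on a Carbonyl Carbon

The source may hold more compounds than are shown below. What is called first, only, known or untested is meant among the compounds shown, and "the series" means these compounds.

In a functional assay on MDA-MB-231 cells (Homo sapiens) for antiproliferative activity, read by MTT assay, with a stated time of 72 h (a lower number here means a stronger inhibitor, a higher number a weaker inhibitor), compound 1 (`CC1=CC[C@H]2[C@H](CC[C@]2(C)O)C(C)(C)[C@@H]1CC[C@H]1[C@]2(C)CC[C@H](OC(=O)c3ccc(C)cc3)C(C)(C)O[C@H]2CC[C@@]1(C)O`) gives 33400 nM, and compound 2 (`CC1=CC[C@H]2[C@H](CC[C@]2(C)O)C(C)(C)[C@@H]1CC[C@H]1[C@]2(C)CC[C@H](OC(=O)c3ccc(C(F)(F)F)cc3)C(C)(C)O[C@H]2CC[C@@]1(C)O`) gives 19500 nM. Compound 2 therefore stands level with compound 1, the two numbers lying within the scatter of each other. Compound 3 (`CC1=CC[C@H]2[C@H](CC[C@]2(C)O)C(C)(C)[C@@H]1CC[C@H]1[C@]2(C)CC[C@H](OC(=O)c3ccc(Cl)c(Cl)c3)C(C)(C)O[C@H]2CC[C@@]1(C)O`) keeps the shared core but has 3,4-dichlorophenyl in place of 4-(trifluoromethyl)phenyl on a carbonyl carbon. Among the compounds with values here, only one measured step bears on this change: a 1.7-fold lower number from compound 1 to compound 2 (0.23 log units; within the scatter), with trifluoromethyl in place of methyl on an aromatic carbon. Within the data shown here, no measured compound carries 3,4-dichlorophenyl, so this step is only a loose guide. Since it stayed small, no clear shift in either direction is expected in this assay. For compound 3, the expected step is a 1.1-fold lower number from compound 2 to compound 3 (0.03 log units; within the scatter). Compound 3 is estimated at 18000 nM, with an expected range of 8000 nM to 38000 nM.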

Compound 3, half-maximal inhibitory concentration: 8100 nM
For compound 3 the middle estimate is 2.2-fold (0.35 log units) above the measured one, and the stated range covers the measured number.
By their numbers in this assay, from the lowest: compound 3; then compounds 2 and 1 (each within the scatter of the next).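

In this assay this position proved able to respond to a change of aromatic group, which the within-scatter pair of compound 1 and compound 2 had not shown: 3,4-dichlorophenyl brings a 2.4-fold lower number from compound 2 to compound 3 (0.38 log units; beyond the scatter) and a 4.1-fold lower number from compound 1 to compound 3 (0.62 log units; beyond the scatter) on the same shared core. Both steps are modest, but they show that the group on this carbonyl carbon can shift the number beyond ordinary repeat variation. No supporting measurement is available to explain this shift.

Going by these compounds, whether both chlorines are needed stays open, as a plain phenyl or a ring carrying only one chlorine would be required to separate their contributions. On these data alone, it is also open how this position would respond to a carboxylic acid or an amine on the aromatic ring.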